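Replacing a Chloromethyl Group with a Cyclopentylmethyl Urea

A few compounds are considered here, and "the series" means these few. Any claim that something is new, unique, unknown or untested is made for them only; others in the source may bear on it.

Within the data shown here, the three compounds measured so far share one core and differ only at two places. Compound 1 `CC(C)c1ccccc1OS(=O)(=O)c1ccc(NC(=O)CCl)cc1` gives 2900 nM in a functional assay on MCF7 cells (Homo sapiens) for antiproliferative activity, read by sulforhodamine B assay, with a stated time of 48 h; a higher number here means a weaker inhibitor, a lower number a stronger inhibitor. Compound 2 `O=C(CCl)Nc1ccc(S(=O)(=O)Oc2ccccc2I)cc1` gives 2500 nM in this assay, and compound 3 `CCCNC(=O)Nc1ccc(S(=O)(=O)Oc2ccccc2C(C)C)cc1` gives 2700 nM. The change from compound 1 to compound 2, iodo in place of isopropyl on an aromatic carbon, reads a 1.2-fold lower number from compound 1 to compound 2 (0.06 log units; within the scatter). The change from compound 1 to compound 3, propylamino in place of chloromethyl on a carbonyl carbon, reads a 1.1-fold lower number from compound 1 to compound 3 (0.03 log units; within the scatter). Compound 2 and compound 3 thus show values that sit very close together, and all three numbers lie within the scatter of one another.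

Compound 4 `O=C(NCC1CCCC1)Nc1ccc(S(=O)(=O)Oc2ccccc2I)cc1` has not been measured. It differs from compound 2 by (cyclopentylmethyl)amino in place of chloromethyl on a carbonyl carbon. Among the measured compounds shown here, the one measured step that bears on this change is the step from compound 1 to compound 3, where an amino group also replaced chloromethyl on the carbonyl carbon and gave a 1.1-fold lower number from compound 1 to compound 3 (0.03 log units; within the scatter). Since that step stayed within the scatter, the expected step from compound 2 to compound 4 in this assay is a 1.0-fold lower number from compound 2 to compound 4 (0.02 log units; within the scatter), with no direction claimed beyond the scatter. Compound 4 is therefore estimated to give 2400 nM in this assay, within a range from 1000 nM to 6000 nM.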

Compound 4, half-maximal inhibitory concentration: 6600 nM
The estimate for compound 4 lay 2.8-fold (0.44 log units) below the measured number, and the stated range ends below it.
By their numbers in this assay, from the lowest: compounds 2, 3 and 1 (each within the scatter of the next); then compound 4.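

Among these compounds, at this carbonyl carbon the group does matter in this assay: with the iodo group held constant, (cyclopentylmethyl)amino in place of chloromethyl gives a 2.6-fold higher number from compound 2 to compound 4 (0.42 log units; beyond the scatter), a modest loss of potency and the first step in this set to lie beyond the scatter. The earlier replacement of chloromethyl by propylamino gave a 1.1-fold lower number from compound 1 to compound 3 (0.03 log units; within the scatter), so an amino group on this carbonyl does not by itself guarantee a loss, although that step was taken with isopropyl rather than iodo on the aromatic ring. Nothing measured here explains why the number rises.

The two steps differ in both the entering group and the aromatic group, so the compounds shown leave open whether the loss follows the cyclopentylmethyl group, depends on its pairing with iodo, or both. Other amino groups on the same carbonyl carbon, such as a straight hexylamino chain or a cyclohexylmethylamino group, would help show whether the ring or simply the size of the entering group tracks with the change.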